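A few compounds are considered here, and "the series" means these few. Any claim that something is new, unique, unknown or untested is made for them only; others in the source may bear on it.

Of the compounds shown here, three have been read so far in a physicochemical assay for solubility, measured as kinetic solubility; on this read-out higher numbers stand for higher solubility and lower numbers for lower solubility. Compound 1, `CNC(=O)c1cc(C(=O)N[C@H]2CC[C@H](O)CC2)c([C@@H](C)c2cccc(Cl)c2)o1`, has a limit of >= 179 ug/mL and not a number. Compound 2, `CC(=O)Nc1c(F)cc(C(=O)N[C@H]2CC[C@H](O)CC2)cc1O[C@@H](C)c1ccccc1`, also has only a limit, >= 159 ug/mL. Compound 3, `CNC(=O)c1cc(C(=O)N[C@H]2[C@@H]3C[C@H](O)C[C@@H]32)n([C@@H](C)c2cccc(Cl)c2)n1`, likewise has only a limit, >= 168 ug/mL. Compound 1 therefore stands among three limits, with no exact number to place it against the other two.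

The next compound, compound 4, `CNC(=O)c1cc(C(=O)N[C@H]2CC[C@H](O)CC2)c([C@@H](C)c2cccc(OC)c2)o1`, keeps the core of compound 1 and changes a single group: methoxy in place of chloro on an aromatic carbon. This puts methoxy in place of chloro on an aromatic carbon, turning 3-chlorophenyl into 3-methoxyphenyl. For the measured compounds named here, no measured pair here shows what such a swap does, so in this assay the expectation is no step beyond the usual scatter, in either direction. That expectation starts from compound 1 and its limit of >= 179 ug/mL. The estimate means a small expected step of an at least 1.0-fold lower number from compound 1 to compound 4 (0.00 log units; that floor lies within the scatter). For compound 4 the estimated solubility is 175 ug/mL, with an expected range of 120 ug/mL to 200 ug/mL.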

Compound 4, solubility: >= 113 ug/mL
Compound 4 gave a limit, no number (the forecaster's own chance of this, stated with the estimate: 70%); the middle value is on the limit's open side.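

In this assay, for the compounds shown here, compound 1 and compound 4 both gave only limits, not numbers, so no step between them can be read. The compounds shown leave open whether methoxy in place of chloro on an aromatic carbon shifts this read-out at all, and in which direction.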